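A few compounds are considered here, and "the series" means these few. Any claim that something is new, unique, unknown or untested is made for them only; others in the source may bear on it.

Measured so far:
- compound 1, `COc1nc(-c2cc3ccccc3o2)cc(-c2ccc(F)cc2)c1C#N`, in a functional assay on aorta (strain Wistar) for inhibition, with Thoracic aorta (Rattus norvegicus) as the target (a lower number here means a stronger inhibitor, a higher number a weaker inhibitor), compound 1 gives 321000 nM
- compound 2, `CCOc1nc(-c2cc3ccccc3o2)cc(-c2ccc(F)cc2)c1C#N`, compound 2 gives 396000 nM
- compound 3, `COc1nc(-c2cc3ccccc3o2)cc(-c2ccc(N(C)C)cc2)c1C#N`, compound 3 gives 278000 nM

The three measured compounds share one core and differ only at two places. From compound 1 to compound 2 the change is methyl in place of hydrogen on a saturated chain carbon bound to an oxygen on an aromatic ring, and it gave a 1.2-fold higher number from compound 1 to compound 2 (0.09 log units; within the scatter). From compound 1 to compound 3 the change is dimethylamino in place of fluoro on an aromatic carbon, with a 1.2-fold lower number from compound 1 to compound 3 (0.06 log units; within the scatter). All three numbers therefore sit close together.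

Compound 4, `CCOc1nc(-c2cc3ccccc3o2)cc(-c2ccc(N(C)C)cc2)c1C#N`, has not been measured. It differs from compound 3 by methyl in place of hydrogen on a saturated chain carbon bound to an oxygen on an aromatic ring, at the same place as in the change from compound 1 to compound 2, so this is the same change made on a second core. The cores themselves differ by the change from compound 1 to compound 3 told above. Among the measured compounds shown here, the expectation for compound 4 rests on the one example at hand: the step from compound 1 to compound 2 stayed within the scatter, so from compound 3 to compound 4 a similarly small step is expected, a 1.2-fold higher number from compound 3 to compound 4 (0.07 log units; within the scatter), because of a 1.2-fold higher number from compound 1 to compound 2 (0.09 log units; within the scatter). With a single prior case the range is kept wide. Compound 4 is therefore estimated at 330000 nM, expected between 150000 nM and 700000 nM.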

Compound 4, half-maximal inhibitory concentration: 338000 nM
Beside the measured number, compound 4's estimate is 1.0-fold (0.01 log units) below it; measured number inside the range.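

Turning methoxy into ethoxy on the core of compound 3 gives a 1.2-fold higher number from compound 3 to compound 4 (0.08 log units; within the scatter) in this assay, and this step matches the one on the core of compound 1: the same change on two cores in this assay, a 1.2-fold higher number (0.09 log units; within the scatter) from compound 1 to compound 2 and a 1.2-fold higher number (0.08 log units; within the scatter) from compound 3 to compound 4, 1.0-fold (0.01 log units) apart, within the scatter of two such steps

Dimethylamino in place of fluoro, now made on the ethoxy compounds, gives a 1.2-fold lower number from compound 2 to compound 4 (0.07 log units; within the scatter), and this step also matches its earlier counterpart: the same change on two cores in this assay, a 1.2-fold lower number (0.06 log units; within the scatter) from compound 1 to compound 3 and a 1.2-fold lower number (0.07 log units; within the scatter) from compound 2 to compound 4, 1.0-fold (0.01 log units) apart, within the scatter of two such steps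

So each change stays small on both cores, but all of these steps lie within the scatter, so the agreement shows only that neither change made a measurable difference here, not that a real effect carries from one core to another, and two cores cannot speak for the rest of the series.

The compounds shown leave open whether a longer chain, such as butoxy in place of ethoxy, would give a step beyond the scatter. They also leave open what a carboxylic acid or a primary amine would do on the aromatic carbon that holds fluoro or dimethylamino.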